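Fluoro for Bromo in a Benzamide Pair

A few compounds are considered here, and "the series" means these few. Any claim that something is new, unique, unknown or untested is made for them only; others in the source may bear on it.

Compound 1 `Nc1ccccc1NC(=O)c1ccc(CSc2ccc(Br)cc2)cc1` was tested in a functional assay on HeLa cells (Homo sapiens) for inhibition, read by CCK-8 assay, with a stated time of 72 h, tested at 2 uM (on this read-out higher numbers stand for more inhibition of growth at the one concentration tested and lower numbers for less inhibition of growth), where compound 1 gives 18.8%. For the measured compounds named here, only one other compound has a number in this assay: compound 2 `Nc1ccccc1NC(=O)/C=C/c1ccc(CSc2ccc(Cl)cc2)cc1`, which in this assay gives 1.94%. Compound 1 thus holds the higher of the two numbers, and the gap between compound 1 and compound 2 lies beyond the scatter of the measurement. Compound 3 `Nc1ccccc1NC(=O)c1ccc(CSc2ccc(F)cc2)cc1` has not yet been measured in this assay. It differs from compound 1 in one place only: fluoro in place of bromo on an aromatic carbon. Going by the values given here, no pair of measured compounds differs from each other in just this way, so no measured step shows what such a swap does here. With one halogen replaced by another on the same aromatic carbon, and nothing else changed, only a small step is expected, most likely a mild fall in growth inhibition or none beyond the scatter. Compound 3 is therefore expected to give about 12% in this assay, within a range from 0% to 28%, which corresponds to an expected step of a number 6.8 percentage points lower from compound 1 to compound 3 (within the scatter).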

Compound 3, percent growth inhibition at one concentration: 27.9%
Estimate against measurement, compound 3: 15.9 percentage points below; measured number inside the range.
By their numbers in this assay, from the lowest: compound 2; then compounds 1 and 3 (each within the scatter of the next).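

The first swap read at this place, on an aromatic carbon para to a large group, is fluoro in place of bromo, and in this assay it gives a number 9.1 percentage points higher from compound 1 to compound 3 (within the scatter). The earlier compounds shown here offered no such reading, since compound 1 and compound 2 differ in more than one place. This single pair shows that, on this read-out, the 4-bromophenyl and 4-fluorophenyl forms of the shared core cannot be told apart, so the exchange of these two halogens at this position leaves growth inhibition level within the usual scatter; nothing measured here speaks to the reason for this result.

The compounds shown leave open whether a group other than a halogen on the same aromatic carbon, such as an amine, a methoxy group or a carboxylic acid, would move the number beyond the scatter. Also open, as far as these compounds go, is how the core would read with an oxygen in place of the sulfur of the sulfanyl link, or with a longer chain there.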